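The compounds below may be only part of what the source reports. "The series", "measured", "known", "first", "only" and "open" are said of these compounds alone.

Of the compounds shown here, three built on a shared core have been measured in a functional assay on HCT-116 cells (Homo sapiens) for cytotoxicity, read by MTT assay, with a stated time of 48 h, in the presence of a further agent that is not named here; a higher number here means that more compound is needed for the effect, a lower number that less compound is needed. Compound 1 `CC(C)c1cc(NNC(=O)Nc2cc(Cl)nc(Cl)c2)nc2c1c(C(F)(F)F)nn2C` gives 27200 nM in this assay. Compound 2 `Cc1nn(C)c2nc(NNC(=O)Nc3cc(Cl)nc(Cl)c3)cc(-c3ccc(F)cc3)c12` gives 25200 nM, the lowest of the three numbers; the number of compound 1 lies within the scatter of it, so no order can be read between those two. Compound 3 `COc1cc(NC(=O)NNc2cc(-c3ccc(F)cc3)c3cnn(C)c3n2)cc(Cl)n1` gives 75300 nM, a higher number than that of compound 2 and beyond the scatter; these two structures differ in more than one place, so the gap is only what their two values show.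

Compound 4 `Cc1nn(C)c2nc(NNC(=O)Nc3cc(Cl)nc(Cl)c3)cc(-c3ccccc3)c12` has not yet been measured. It differs from compound 2 in a single place: hydrogen in place of fluoro on an aromatic carbon. Among the compounds with values here, no pair of measured compounds here differs by that change alone, so no measured step guides the expectation. The change trades a single fluorine for a hydrogen, and the step from compound 2 to compound 4 is expected to be small, in either direction, with no good reason to expect one beyond the scatter; a slightly higher number is taken as the somewhat more likely outcome. The step that this expectation means is a 1.3-fold higher number from compound 2 to compound 4 (0.10 log units; within the scatter). On that basis compound 4 is estimated at 32000 nM in this assay, with a range from 13000 nM to 80000 nM.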

Compound 4, half-maximal effective concentration: 80000 nM
Compound 4: middle estimate off by 2.5-fold (0.40 log units), on the low side, within the range that was stated.
By their numbers in this assay, from the lowest: compounds 2 and 1 (each within the scatter of the next); then compounds 3 and 4 (each within the scatter of the next).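

In this assay, the change from 4-fluorophenyl to phenyl gives a 3.2-fold higher number from compound 2 to compound 4 (0.50 log units; beyond the scatter), the only step among these compounds that isolates a single place. It shows that this position, para to a large group on a six-membered aromatic ring of carbon only, is not indifferent to the exchange of fluoro for hydrogen. The step is modest but lies beyond the scatter, even though the change removes only one heavy atom and alters no ring, hydrogen-bond donor or acceptor count, or net charge. Nothing available explains why the number moves in this direction.

The compounds shown leave open whether the higher number follows from the loss of fluoro in particular or whether other groups at this place, such as chloro, methoxy or an amine, would give values nearer that of compound 2. They also leave open whether the same change would give a similar step on compound 3, which carries the same 4-fluorophenyl group but differs from compound 2 in more than one place.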